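The compounds below may be only part of what the source reports. "The series", "measured", "known", "first", "only" and "open" are said of these compounds alone.

In a functional assay on T-24 cells (Homo sapiens) for antiproliferative activity, read by MTT assay, with a stated time of 72 h (on this read-out lower numbers stand for stronger inhibition and higher numbers for weaker inhibition), compound 2 (`CCN(CC)C(=N)NC(=N)Nc1ccc(F)c(F)c1`) gives 44800 nM. Compound 1 (`CC(C)CNC(=N)NC(=N)Nc1ccc(F)c(F)c1`) gives 42900 nM, so the two cannot be told apart. Compound 3 (`CCN(C)C(=N)NC(=N)Nc1ccc(C(F)(F)F)cc1`), at 5700 nM, lies lower than both, but it differs from compound 2 in more than one place and so offers no single-change comparison. Compound 4 (`N=C(NC(=N)NC1CCCC1)Nc1ccc(F)c(F)c1`) changes one group of compound 2: cyclopentylamino in place of diethylamino on a carbon with a double bond to nitrogen. In words, cyclopentylamino stands in place of diethylamino on a carbon with a double bond to nitrogen.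

Within the data shown here, one measured step bears on this change, because it falls at the same place: a 1.0-fold higher number from compound 1 to compound 2 (0.02 log units; within the scatter). There, diethylamino replaced isobutylamino and the number stayed within the scatter. Among the measured compounds shown here, that is thin evidence, since it is a single step and no measured compound carries a ring at this place. Going by that one step, the expectation is a small change at most, with nothing beyond the scatter and a slight lean towards a lower number. The estimated move is a 1.5-fold lower number from compound 2 to compound 4 (0.17 log units; within the scatter). In this assay, compound 4 is expected at 30000 nM, with an estimated range of 12000 nM to 60000 nM.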

Compound 4, half-maximal inhibitory concentration: 24900 nM
For compound 4 the middle estimate is 1.2-fold (0.08 log units) above the measured one, and the stated range covers the measured number.
By their numbers in this assay, from the lowest: compound 3; then compounds 4, 1 and 2 (each within the scatter of the next).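

In this assay, among these compounds, this place now carries a ring for the first time, and cyclopentylamino on a carbon with a double bond to nitrogen gives a 1.8-fold lower number from compound 2 to compound 4 (0.26 log units; within the scatter) and, set against the isobutyl chain, a 1.7-fold lower number from compound 1 to compound 4 (0.24 log units; within the scatter). Across compounds 1, 2 and 4, this place has therefore held two open chains and one five-membered non-aromatic ring of carbon only, and no step among them goes beyond the scatter, even where the entering group brings a hydrogen-bond donor that diethylamino lacks. No measurement on hand offers a reason for this result or ties it to any property of these groups.

As far as these compounds go, the three groups tried on this core span only a narrow set of shapes, so it remains open whether a larger ring such as cyclohexyl, a ring holding a second nitrogen such as piperazine, or a chain ending in a hydroxyl or a carboxylic acid would move the number beyond the scatter. From the compounds shown here alone, it is also open whether cyclopentylamino would behave the same way alongside the trifluoromethyl group of compound 3, which differs from compound 4 in more than one place and so cannot be compared with it directly.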